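The source may report more compounds than this note shows. Statements on the series, on what has been measured and on what is new or still open speak of the compounds shown alone.

Series notes. The shared core appears in compound 2 `Cn1cc(C2=C(c3nn(CCCO)c4ncccc34)C(=O)NC2=O)c2ccccc21`, in compound 1 `Cn1cc(C2=C(c3nn(CCCN4CCCCC4)c4ncccc34)C(=O)N(c3ccccn3)C2=O)c2ccccc21`, in compound 3 `Cn1cc(C2=C(c3nn(CCCN4CCCCC4)c4ncccc34)C(=O)N(c3ccccc3)C2=O)c2ccccc21` and in the unmeasured compound 4 `Cn1cc(C2=C(c3nn(CCCn4cncn4)c4ncccc34)C(=O)NC2=O)c2ccccc21`. In a functional assay on SMMC-7721 cells (Homo sapiens) for antiproliferative activity, read by MTT assay, with a stated time of 48 h (a higher number here means a weaker inhibitor, a lower number a stronger inhibitor), compound 2 gives only a limit, > 100000 nM. Compound 1 likewise reaches only a limit in this assay, > 100000 nM. Compound 3 gives 3050 nM in this assay. Compound 2 thus stands at the limit of > 100000 nM in this assay, at which 2 of the 3 values shown sit, and no number is known for it; its place among the three cannot be ranked beyond that.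

Compound 4 differs from compound 2 by 1H-1,2,4-triazol-1-yl in place of hydroxy on a saturated chain carbon, three bonds along the chain from an aromatic nitrogen. Among the measured compounds shown here, the only measured step, an at least 32-fold lower number from compound 1 to compound 3 (1.51 log units; beyond the scatter), concerns the amide-type nitrogen in a ring and not the chain, so no measured step bears on the present change, and its direction is open. With compound 2 at a limit, the step of a number no higher from compound 2 to compound 4 (the limit leaves the size open) is taken as the expected working figure, and a result that is again only a limit remains likely. Compound 4 is estimated at 100000 nM, between 20000 nM and 300000 nM.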

Compound 4, half-maximal inhibitory concentration: > 100000 nM
Compound 4: only a limit was reported; the forecaster's own chance of this, stated with the estimate: 60%; the middle value sits exactly at the limit.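

In this assay, among the compounds shown here, compound 2 and compound 4 both give only a limit, so no step between them can be read: the limit of > 100000 nM in this assay, at which 3 of the 4 values shown sit. The compounds shown leave open whether 3-(1H-1,2,4-triazol-1-yl)propyl in place of 3-hydroxypropyl changes antiproliferative activity at all.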